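Hydrogen for Fluoro: From Compound 2 to Compound 3

A few compounds are considered here, and "the series" means these few. Any claim that something is new, unique, unknown or untested is made for them only; others in the source may bear on it.

compound 1 `COc1ccc(-c2cn(C/C=C3\OC(=O)C(OCc4ccccc4)=C3OCc3ccccc3)nn2)cc1`: > 100000 nM
compound 2 `O=C1O[C@H]([C@@H](O)Cn2cc(CNS(=O)(=O)c3ccc(Cl)cc3F)nn2)C(OCc2ccccc2)=C1OCc1ccccc1`: 39100 nM

Among the measured compounds shown here, in a functional assay on A549 cells (Homo sapiens) for antiproliferative activity, read by MTT assay, with a stated time of 72 h (a higher number here means a weaker inhibitor, a lower number a stronger inhibitor), compound 2 gives 39100 nM, the only plain number in this small set. Compound 1 is reported only as a limit of this assay, > 100000 nM; this is the case described by the limit of > 100000 nM in this assay, at which 1 of the 2 values shown sits. For the measured compounds named here, no two measured compounds differ in just one place, so no measured step is available.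

Compound 3 `O=C1O[C@H]([C@@H](O)Cn2cc(CNS(=O)(=O)c3ccc(Cl)cc3)nn2)C(OCc2ccccc2)=C1OCc1ccccc1` differs from compound 2 by hydrogen in place of fluoro on an aromatic carbon. A change of a single fluorine for hydrogen on an aromatic carbon is expected to shift this assay only a little, with no direction that can be justified from the data, and most likely not beyond the scatter. Compound 3 is therefore expected to give about 45000 nM, within a range of 15000 nM to 120000 nM. The expected step is a 1.2-fold higher number from compound 2 to compound 3 (0.06 log units; within the scatter), within the scatter.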

Compound 3, half-maximal inhibitory concentration: 2870 nM
Compound 3: middle estimate off by 16-fold (1.20 log units), on the high side; measured number outside the range, below it.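

In this assay, among the compounds shown here, hydrogen in place of fluoro, the change from 4-chloro-2-fluorophenyl to 4-chlorophenyl, gives a 14-fold lower number from compound 2 to compound 3 (1.13 log units; beyond the scatter), the first one-place comparison in this set. It shows that this position on the aromatic ring, ortho to a large group and meta to a chloro group, is sensitive in this assay, and that the fluoro is unfavourable there. For the compounds shown here, the change involves only one heavy atom, with no ring, hydrogen-bond donor, hydrogen-bond acceptor or net charge leaving, and nothing given here bears on why it moves the number so far.

The compounds shown leave open whether a chloro, methyl or methoxy group at this position would also weaken the compound or whether the loss is particular to fluoro. They also leave open whether the same step would appear if the chloro group were exchanged for another substituent.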